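Notes: isopropyl in place of methyl on an aromatic nitrogen

This account rests on a few compounds, and the source may have more. Where it says the series, first, only, none or still open, it means among the compounds named here.

Measured so far in a physicochemical assay for lipophilicity, using the shake flask method, at pH 7.4 (on this read-out higher numbers stand for higher lipophilicity and lower numbers for lower lipophilicity), for two compounds
- compound 1 `Cn1ccc2ncnc(N[C@H]3CC[C@H](N(C)C)CC3)c21` gives -0.8
- compound 2 `Cc1ccn2ncnc(N[C@H]3CC[C@H](N(C)C)CC3)c12` gives 0.2

Compound 1 holds the lower of the two numbers, and compound 2 stands higher by a gap beyond the scatter. For the measured compounds named here, no measured pair differs in one place only, so the series offers no direct precedent for the next step, and the gap between these two compounds cannot be read as a guide to it.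

Going by the values given here, compound 3 `CC(C)n1ccc2ncnc(N[C@H]3CC[C@H](N(C)C)CC3)c21` keeps the shared core of compound 1 and carries isopropyl in place of methyl on an aromatic nitrogen as its only change. The expected move in this assay is upward, with a number 0.70 log units higher from compound 1 to compound 3 (beyond the scatter) as the estimated step, which would lie beyond the scatter. Among the compounds with values here, this expectation rests on the structural change alone and has no measured pair behind it. The starting point is compound 1 at -0.8 in this series. Compound 3 is estimated at -0.1 with an expected range from -0.5 to 0.3 until a measurement is available.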

Compound 3, distribution coefficient: 0.1
Beside the measured number, compound 3's estimate is 0.20 log units below it; the measured number falls inside the stated range.
By their numbers in this assay, from the lowest: compound 1; then compounds 3 and 2 (each within the scatter of the next).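

Isopropyl in place of methyl on an aromatic nitrogen gives the series its first pair that differs in one place only, and in this assay this change gives a number 0.90 log units higher from compound 1 to compound 3 (beyond the scatter), a modest step. The read-out therefore responds to the group on this aromatic nitrogen of the five-membered aromatic ring, with the rest of the structure of compound 1 held constant, and methyl and isopropyl are now directly comparable at this position. No supporting data bear on why the step has this size, so it stands as an observation on a single pair.

On these data alone, a single pair gives one step and no trend, so it remains open how this assay would read with a longer chain, a cyclopropyl group or a hydroxyethyl group on the same aromatic nitrogen. Also open is whether isopropyl in place of methyl would give a similar step on a different core, since the compounds shown contain only this one example of the change.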